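Swapping a Benzoyl Phenyl for Furan on a Shared Core

This account rests on a few compounds, and the source may have more. Where it says the series, first, only, none or still open, it means among the compounds named here.

Of the compounds shown here, two of one family have been tested so far. Compound 1 `Cc1cccc(COc2cccc(/C=C3\C(=O)NN(C(=O)c4ccncc4)C3=O)c2)c1`, in a functional assay on cells for agonist activity at Bile acid receptor (Homo sapiens), read by a luciferase reporter (on this read-out higher numbers stand for an effect only at larger amounts of compound and lower numbers for an effect already at smaller amounts), gives 2400 nM. Compound 2 `O=C1NN(C(=O)c2ccccc2)C(=O)/C1=C/c1ccc(OCc2ccccc2)cc1` gives in this assay 3980 nM; the values of compound 2 and compound 1 lie within the usual scatter of each other, so neither can be called stronger or weaker on these data.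

Compound 3 `O=C1NN(C(=O)c2ccco2)C(=O)/C1=C/c1ccc(OCc2ccccc2)cc1` differs from compound 2 in one place: furan-2-yl in place of phenyl on a carbonyl carbon, that is, benzoyl to (furan-2-yl)carbonyl, with the rest of the molecule unchanged. For the measured compounds named here, no measured pair shows what such an exchange does here, so the step has to be estimated from compound 2 alone, and a small step in either direction, not clearly beyond the scatter, is the expectation.

Compound 3 is therefore expected to give about 3500 nM, within the range 1200 nM to 10000 nM, and the expected step is a 1.1-fold lower number from compound 2 to compound 3 (0.06 log units; within the scatter).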

Compound 3, half-maximal effective concentration: 3310 nM
The estimate for compound 3 lay 1.1-fold (0.02 log units) above the measured number; low and high end bracket the measured number.
By their numbers in this assay, from the lowest: compounds 1, 3 and 2 (each within the scatter of the next).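

Furan-2-yl in place of phenyl on this carbonyl carbon, whose other neighbour is an amide-type nitrogen in a ring, gives the first measured step in this family: in this assay it is a 1.2-fold lower number from compound 2 to compound 3 (0.08 log units; within the scatter), so the two compounds cannot be told apart on this read-out. A six-membered aromatic ring of carbon only and a five-membered aromatic ring with one hetero atom can therefore stand at this place with equal results, at least for this pair. Nothing measured here bears on why the two rings read alike.

Still open, from the compounds shown here alone, is whether an aromatic ring is needed here at all, which a plain methyl group or a saturated cyclohexyl ring would test. Also open, going by these compounds, is whether a ring carrying an amine or a carboxylic acid at this place would move the number beyond the scatter.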